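Bromo for chloro on the benzoyl ring of compound 3

The compounds below may be only part of what the source reports. "The series", "measured", "known", "first", "only" and "open" are said of these compounds alone.

Working notes on a small set of ethyl ester triazoles read in a functional assay on the whole organism (strain albino) for inhibition, with Rattus norvegicus as the target, read by paw edema, with stated times of 30 min and 3 h, at a dose of 5 mg/kg by the oral route; a higher number here means more inhibition at the dose given (going by the name of the read-out), a lower number less inhibition. Compound 1 `CCOC(=O)Cc1n[nH]c(N)n1` carries no group on the ring nitrogen and gives 51.8%. Compound 2 `CCOC(=O)Cc1nc(N)n(C(=O)c2ccccc2)n1` bears a benzoyl on that nitrogen and gives 57.5%. Compound 3 `CCOC(=O)Cc1nc(N)n(C(=O)c2ccc(Cl)cc2)n1` bears a 4-chlorophenyl in place of the phenyl and gives 62.8%. Compound 3 lies beyond the scatter above compound 1, while its gap to compound 2 is within the scatter, so no order between compound 2 and compound 3 can be read. Among the measured compounds shown here, the one step to compound 3, a number 5.3 percentage points higher from compound 2 to compound 3 (within the scatter), was within the scatter.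

Compound 4 `CCOC(=O)Cc1nc(N)n(C(=O)c2ccc(Br)cc2)n1` is not yet measured. It differs from compound 3 by bromo in place of chloro on an aromatic carbon. For the measured compounds named here, the only step that bears on it is the chloro step, and that step was within the scatter, so a bromo in the same place is not expected to move the number beyond the scatter in either direction. The expected step is a number 1.2 percentage points higher from compound 3 to compound 4 (within the scatter). Compound 4 is therefore estimated at 64%, in the range 52% to 76%.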

Compound 4, a percentage reported as inhibition, in the whole organism at one dose (the size of the read-out at that dose, not a potency): 64.1%
Beside the measured number, compound 4's estimate is 0.1 percentage points below it; measured number inside the range.
By their numbers in this assay, from the lowest: compounds 1, 2, 3 and 4 (each within the scatter of the next, the first and the last beyond it).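

In this assay the exchange of chloro for bromo at the aromatic carbon para to a large group gives a number 1.3 percentage points higher from compound 3 to compound 4 (within the scatter) and so does not separate the two halogens at this position. Set against the unsubstituted benzoyl, bromo in place of hydrogen gives a number 6.6 percentage points higher from compound 2 to compound 4 (within the scatter) and so, like the chloro step before it, shows no order between the halogen-bearing compound and compound 2. A second halogen at this place thus adds a further step that stays within the scatter, and nothing here gives a reason for the values.

Still open, as far as these compounds go, is whether a group of another kind at this place, such as a methoxy, an amine or a carboxylic acid, would move the number beyond the scatter. Also open, from the compounds shown here alone, is how the series would read with a carboxylic acid or an amide in place of the ethyl ester.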